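A few compounds are considered here, and "the series" means these few. Any claim that something is new, unique, unknown or untested is made for them only; others in the source may bear on it.

Of the compounds shown here, three sharing one core have numbers so far in a functional assay on CCRF-CEM cells (Homo sapiens) for inhibition, read by MTT assay, with a stated time of 72 h (a lower number here means a stronger inhibitor, a higher number a weaker inhibitor), for this series. Compound 1 `COc1cc(NC(C)CCCNC(=O)Nc2cccc(F)c2)c2ncccc2c1` gives 21000 nM and compound 2 `COc1cc(NC(C)CCCNC(=O)Nc2cccc(Cl)c2)c2ncccc2c1` gives 22000 nM in this test. Compound 3 `COc1cc(NC(C)CCCNC(=O)NNC(=O)Nc2ccc(Br)cc2)c2ncccc2c1` gives 110000 nM as the highest of the three numbers, which makes it the weakest inhibitor here. Compound 4 `COc1cc(NC(C)CCCNC(=O)Nc2cccc(O)c2)c2ncccc2c1` still awaits measurement. The change from compound 3 is 3-hydroxyphenyl in place of ((4-bromophenyl)carbamoyl)amino on an amide-type nitrogen and it puts 3-hydroxyphenyl in place of ((4-bromophenyl)carbamoyl)amino on an amide-type nitrogen. Compound 4 thus returns to the kind of substituted phenyl group carried by compound 1 and compound 2. Two measured steps run the opposite way, a 5.2-fold higher number from compound 1 to compound 3 (0.72 log units; beyond the scatter) and a 5.0-fold higher number from compound 2 to compound 3 (0.70 log units; beyond the scatter) and both are modest but beyond the scatter. Chloro in place of fluoro gave a 1.0-fold higher number from compound 1 to compound 2 (0.02 log units; within the scatter) and that lies within the scatter. For the measured compounds named here, no hydroxy compound has been measured, so some uncertainty remains. The estimated step is a 4.4-fold lower number from compound 3 to compound 4 (0.64 log units; beyond the scatter) and it is expected to point towards a stronger inhibitor. The expected value for compound 4 is 25000 nM within an estimated range from 10000 nM to 60000 nM in this test.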

Compound 4, half-maximal inhibitory concentration: 32000 nM
Estimate against measurement, compound 4: 1.3-fold (0.11 log units) below; low and high end bracket the measured number.
By their numbers in this assay, from the lowest: compounds 1, 2 and 4 (each within the scatter of the next); then compound 3.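

In this assay, 3-hydroxyphenyl in place of the larger ((4-bromophenyl)carbamoyl)amino on the amide-type nitrogen gives a modest step beyond the scatter (a 3.4-fold lower number from compound 3 to compound 4 (0.54 log units; beyond the scatter)), so the gain in number seen with the halogen-bearing phenyl compounds is not special to fluoro or chloro. Hydroxy on that aromatic carbon cannot be told apart from either halogen, whether against chloro (a 1.5-fold higher number from compound 2 to compound 4 (0.16 log units; within the scatter)) or against fluoro (a 1.5-fold higher number from compound 1 to compound 4 (0.18 log units; within the scatter)), so in this small set the three groups give equivalent results in this test. No measured evidence here explains why these groups read alike.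

The compounds shown leave open whether an amine or a carboxylic acid on that phenyl ring would also read alike. They also leave open whether a longer chain on the shared core would shift the number for any of these phenyl ureas.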